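The compounds below may be only part of what the source reports. "The series", "measured", "known", "first", "only" and "open" are said of these compounds alone.

Measured so far in a functional assay on HFF cells (Homo sapiens) for cytotoxicity; on this read-out higher numbers stand for weaker inhibition and lower numbers for stronger inhibition:

compound 1, `CCOC[C@H]1O[C@@H](n2c(Cl)nc3cc(Cl)c(Cl)cc32)[C@H](OC(C)=O)[C@@H]1OC(C)=O`, gives 33000 nM
compound 2, `CCCCOC[C@H]1O[C@@H](n2c(Cl)nc3cc(Cl)c(Cl)cc32)[C@H](OC(C)=O)[C@@H]1OC(C)=O`, gives 66000 nM
compound 3, `CCOC[C@H]1OC(n2c(Cl)nc3cc(Cl)c(Cl)cc32)[C@H](O)[C@@H]1O`, gives 26000 nM

Compound 1 and compound 2 share one core and differ in a single place: ethyl in place of hydrogen on a saturated chain carbon, two bonds along the chain from an oxygen on a saturated carbon. This change produced a 2.0-fold higher number from compound 1 to compound 2 (0.30 log units; within the scatter), so on the evidence of this one pair it barely moved the read-out. Compound 3 is built on a different core; the difference between the core of compound 1 and the core of compound 3 is not broken down here. Compound 3 has the lowest of the three numbers, but its gap to compound 1 lies within the scatter, whereas its gap to compound 2 lies beyond it.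

Compound 4, `CCCCOC[C@H]1OC(n2c(Cl)nc3cc(Cl)c(Cl)cc32)[C@H](O)[C@@H]1O`, has not yet been tested in this assay. It relates to compound 3 exactly as compound 2 relates to compound 1: ethyl in place of hydrogen on a saturated chain carbon, two bonds along the chain from an oxygen on a saturated carbon. The place of the change is described in the same words in both pairs, so it is the same change carried onto the core of compound 3. Within the data shown here, the only guide to its effect is the single step it made before, a 2.0-fold higher number from compound 1 to compound 2 (0.30 log units; within the scatter), and one observation on another core is a thin basis. The step from compound 3 to compound 4 is expected to be a 1.9-fold higher number from compound 3 to compound 4 (0.28 log units; within the scatter). Compound 4 is therefore estimated to give about 50000 nM in this assay, with a likely range from 22000 nM to 110000 nM.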

Compound 4, half-maximal inhibitory concentration: 32000 nM
Compound 4: the middle estimate sits 1.6-fold (0.19 log units) above what was measured; the measured number falls inside the stated range.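

In this assay, putting ethyl in place of hydrogen, which turns the ethoxy chain of compound 3 into the butoxy chain of compound 4, gave a 1.2-fold higher number from compound 3 to compound 4 (0.09 log units; within the scatter), so this step cannot be told apart from repeat-measurement noise. Set beside the earlier step, the same change gives results on the two cores that agree within the scatter: the same change on two cores in this assay, a 2.0-fold higher number (0.30 log units; within the scatter) from compound 1 to compound 2 and a 1.2-fold higher number (0.09 log units; within the scatter) from compound 3 to compound 4, 1.6-fold (0.21 log units) apart, within the scatter of two such steps. This shows that, on the two pairs available, going from ethoxy to butoxy carried over from one core to the other without a measurable difference in this read-out, but it does not show that the change has a real effect of its own on either core, nor that the same would hold on a third core.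

The compounds shown leave open what a longer chain than butoxy, or a chain ending in an amine or a carboxylic acid, would do in this assay. They also leave open whether a ring such as phenyl at the end of the chain would produce a step large enough to stand clear of the scatter, which neither pair here does.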